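Notes on the step from compound 3 to compound 4

The source may report more compounds than this note shows. Statements on the series, on what has been measured and on what is new or still open speak of the compounds shown alone.

Measured in a functional assay on SW480 cells (Homo sapiens) for antiproliferative activity, read by sulforhodamine B assay, with a stated time of 48 h; on this read-out higher numbers stand for weaker inhibition and lower numbers for stronger inhibition:
- compound 1 `COc1ccc(/C=C/C(=O)c2ccccc2-c2ccc(F)cc2)cc1`: 61 nM
- compound 2 `COc1ccc(OC)c(/C=C/C(=O)c2ccccc2-c2ccc(F)cc2)c1`: 2400 nM
- compound 3 `COc1ccc(/C=C/C(=O)c2ccccc2-c2cccc(F)c2)cc1`: 140 nM

Compound 3 holds the middle place of the three numbers, with a lower number for compound 1 and a higher one for compound 2. The next compound is compound 4 `COc1ccc(/C=C/C(=O)c2ccccc2-c2cccnc2)cc1`, which has pyridin-3-yl in place of 3-fluorophenyl on an aromatic carbon, ortho to a large group: pyridin-3-yl in place of 3-fluorophenyl on an aromatic carbon.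

For the measured compounds named here, only one measured step bears on this group: a 2.3-fold higher number from compound 1 to compound 3 (0.36 log units; beyond the scatter). Going by the values given here, that step is modest, and no single-place step involves compound 2. Among the compounds with values here, no measured compound has a hetero atom in this ring, so the direction is poorly supported. A modest move toward a higher number in this assay is tentatively expected. The expected change is a 1.8-fold higher number from compound 3 to compound 4 (0.25 log units; within the scatter). For compound 4 the estimated value is 250 nM, with an expected range of 70 nM to 900 nM.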

Compound 4, half-maximal inhibitory concentration: 200 nM
Compound 4: middle estimate off by 1.3-fold (0.10 log units), on the high side; low and high end bracket the measured number.
By their numbers in this assay, from the lowest: compound 1; then compounds 3 and 4 (each within the scatter of the next); then compound 2.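

In this assay, for the compounds shown here, the place tolerates a ring with a hetero atom: pyridin-3-yl in place of 3-fluorophenyl gives a 1.4-fold higher number from compound 3 to compound 4 (0.15 log units; within the scatter) and so stays level with the fluorinated ring, which no earlier compound could show. Set against 4-fluorophenyl, the same group gives a 3.3-fold higher number from compound 1 to compound 4 (0.52 log units; beyond the scatter) as a modest step, so 4-fluorophenyl keeps the lowest number among the three groups read at this place on the shared core. No measurement at hand accounts for these numbers.

As far as these compounds go, whether pyridin-4-yl, or a phenyl ring carrying a carboxylic acid or an aminomethyl group, would stay level with pyridin-3-yl remains open. Also open, from the compounds shown here alone, is whether the pyridin-3-yl step keeps its size on the core of compound 2.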